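A few compounds are considered here, and "the series" means these few. Any claim that something is new, unique, unknown or untested is made for them only; others in the source may bear on it.

Of the compounds shown here, two have been measured in a functional assay on B16-F10 cells (Mus musculus) for antiproliferative activity, read by ELISA and MTT assay, with a stated time of 48 h (a lower number here means a stronger inhibitor, a higher number a weaker inhibitor), so far. Compound 1, `O=C(/C=C/c1ccc(F)cc1)NS(=O)(=O)c1ccc(F)cc1`, gives 0.8 ug/mL in this assay. Compound 2, `O=C(/C=C/c1ccc(Cl)cc1)NS(=O)(=O)c1ccccc1`, gives 2.2 ug/mL in this assay, the higher of the two numbers, and its gap to compound 1 lies beyond the usual scatter. Compound 3, `O=C(/C=C/c1ccc(Cl)cc1)NS(=O)(=O)c1ccc(F)cc1`, is not yet measured; it differs from compound 2 by fluoro in place of hydrogen on an aromatic carbon, sitting on an aromatic carbon of a six-membered aromatic ring of carbon only, para to a large group. Going by the values given here, no measured step of this kind exists here, so a small downward step, or none beyond the scatter, is expected: a 1.5-fold lower number from compound 2 to compound 3 (0.17 log units; within the scatter). Compound 3 is expected near 1.5 ug/mL in this assay, between 0.6 ug/mL and 3.5 ug/mL.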

Compound 3, half-maximal inhibitory concentration: 2 ug/mL
Compound 3: middle estimate off by 1.3-fold (0.12 log units), on the low side; the measured number falls inside the stated range.
By their numbers in this assay, from the lowest: compound 1; then compounds 3 and 2 (each within the scatter of the next).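

In this assay, going from phenyl to 4-fluorophenyl while chloro stays in place makes no difference that stands out from the scatter (a 1.1-fold lower number from compound 2 to compound 3 (0.04 log units; within the scatter)). By contrast, chloro in place of fluoro on an aromatic carbon, with 4-fluorophenyl kept, gives a modest step beyond the scatter (a 2.5-fold higher number from compound 1 to compound 3 (0.40 log units; beyond the scatter)), so of these two single changes, only this one can be read as a real difference. No measurement here explains either step. As far as these compounds go, whether a methoxy group or an amine in place of the fluoro of 4-fluorophenyl would shift the number remains open.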